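Notes on the step from compound 2 to compound 3

The source may report more compounds than this note shows. Statements on the series, on what has been measured and on what is new or still open speak of the compounds shown alone.

- compound 1 (`O=C(Nc1ccc(-c2nc3ccccc3s2)cc1)c1cc([N+](=O)[O-])ccc1Cl`) gives a limit (> 27000 nM)
- compound 2 (`Cc1cc(NC(=O)c2cc([N+](=O)[O-])ccc2Cl)cc(-c2nc3ccccc3o2)c1O`) gives a limit (> 25000 nM)

In an ADME assay on HepG2 cells (Homo sapiens) for cytotoxicity, with a stated time of 72 h (on this read-out lower numbers stand for an effect already at smaller amounts and higher numbers for an effect only at larger amounts of compound), compound 2 stands only at a limit (> 25000 nM). Compound 1 also reaches only a limit (> 27000 nM). Compound 3 (`Cc1cc(NC(=O)c2cc([N+](=O)[O-])ccc2Cl)cc(-c2nc3ccccc3s2)c1O`) has 1,3-benzothiazol-2-yl in place of 1,3-benzoxazol-2-yl on an aromatic carbon. For the measured compounds named here, no measured step covers this change, and no step beyond the scatter is expected in this assay. The estimated step is small (a number no higher from compound 2 to compound 3 (the limit leaves the size open)). Compound 3 is expected near 25000 nM with an estimated range from 10000 nM to 50000 nM (the assay may well report a limit again).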

Compound 3, half-maximal effective concentration: > 25000 nM
Compound 3: a limit, no number (the forecaster's own chance of this, stated with the estimate: 75%); the middle value sits exactly at the limit.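

For the compounds shown here, compound 2 and compound 3 both give only a limit in this assay, and no step between them can be read. The compounds shown leave open whether 1,3-benzothiazol-2-yl in place of 1,3-benzoxazol-2-yl changes this read-out at all.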